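This account rests on a few compounds, and the source may have more. Where it says the series, first, only, none or still open, it means among the compounds named here.

Notes on the series, read in a functional assay on MCF7 cells (Homo sapiens) for antiproliferative activity, read by sulforhodamine B assay, with a stated time of 48 h; on this read-out lower numbers stand for stronger inhibition and higher numbers for weaker inhibition. Compound 1 `CC1(C)[C@@H]2CC3=N[C@@H](CCC(=O)O)C(=O)O[C@@]3(C)[C@H]1C2` gives 38000 nM, and compound 2 `C[C@@H]1N=C2C[C@@H]3C[C@@H](C3(C)C)[C@]2(C)OC1=O` gives 154000 nM. Compound 3 `CC(C)(C)OC(=O)CC[C@H]1N=C2C[C@H]3C[C@H](C3(C)C)[C@@]2(C)OC1=O` gives 54000 nM, which lies within the scatter of the value for compound 1 and beyond the scatter of the value for compound 2.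

Compound 4 `CC(C)(C)OC(=O)CC[C@@H]1N=C2C[C@@H]3C[C@@H](C3(C)C)[C@]2(C)OC1=O` has the same atoms and bonds as compound 3: the two compounds have the same atoms and bonds and differ only in configuration as drawn: 4 of 4 stereo elements differ (all stereocentres are inverted: mirror images); a stereocentre at a saturated ring carbon is drawn R in compound 3 and S in compound 4; a stereocentre at a saturated ring carbon is drawn R in compound 3 and S in compound 4; a stereocentre at a saturated ring carbon is drawn R in compound 3 and S in compound 4; a stereocentre at a saturated ring carbon is drawn R in compound 3 and S in compound 4. All stereocentres are inverted, so the two are mirror images.

Among the measured compounds shown here, the only measured step, a 4.1-fold higher number from compound 1 to compound 2 (0.61 log units; beyond the scatter), replaces carboxymethyl with hydrogen and is not a change of configuration. For the measured compounds named here, it therefore gives no direct size for this inversion, and the series holds no measured pair of mirror images. With no evidence for a shift in either direction, the expectation stays anchored on compound 3 at 54000 nM, with no step beyond the scatter in this assay and wide uncertainty.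

The expected change is a 1.1-fold higher number from compound 3 to compound 4 (0.05 log units; within the scatter). The estimate for compound 4 is 60000 nM, with an expected range from 22000 nM to 150000 nM.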

Compound 4, half-maximal inhibitory concentration: 40000 nM
Compound 4: the middle estimate sits 1.5-fold (0.18 log units) above what was measured; the range from low to high includes it.
By their numbers in this assay, from the lowest: compounds 1, 4 and 3 (each within the scatter of the next); then compound 2.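

In this assay, the first measured inversion in the series gives a 1.4-fold lower number from compound 3 to compound 4 (0.13 log units; within the scatter), so this pair of mirror images shows no separation between the two configurations as drawn: the fact that compounds 3 and 4 differ only in the configuration as drawn. With the configuration of compound 2 kept, (tert-butoxycarbonyl)methyl in place of hydrogen on the saturated chain carbon gives a 3.9-fold lower number from compound 2 to compound 4 (0.59 log units; beyond the scatter), a second reading of the chain's gain from a different compound than the acid. The end of the chain does not separate the two chain-bearing compounds here, as tert-butyl in place of hydrogen on the oxygen gives a 1.1-fold higher number from compound 1 to compound 4 (0.02 log units; within the scatter).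

From the compounds shown here alone, whether inversion stays as silent for the free carboxylic acid of compound 1 remains open. Also open, going by these compounds, is whether an amine at the chain end, or a longer chain, would move the number beyond that of compound 1.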